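The source may report more compounds than this note shows. Statements on the series, on what has been measured and on what is new or still open speak of the compounds shown alone.

Working notes on the series, all read in a functional assay on cells (Platelet, Homo sapiens) for inhibition; a higher number here means a weaker inhibitor, a lower number a stronger inhibitor. Compound 1 (`CCOC(=O)c1cccc(-c2n[nH]c3ccccc23)c1`) gives > 10000 nM, which is a limit and not a number. Compound 3 (`CCOC(=O)c1cccc(-c2nn(Cc3ccccc3)c3ccccc23)c1`) gives > 10000 nM, again a limit. Compound 2 (`CCOC(=O)c1ccc(-c2nn(Cc3ccccc3OC)c3ccccc23)cc1`) gives > 10000 nM, also a limit, so its standing is known only as that limit. The whole set reads as the limit of > 10000 nM in this assay, at which 3 of the 3 values shown sit.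

Compound 4 (`CCOC(=O)c1ccc(-c2nn(CC)c3ccccc23)cc1`) is the next entry, and it departs from compound 2 by methyl in place of 2-methoxyphenyl on a saturated chain carbon bound to an aromatic nitrogen. In words, this is methyl in place of 2-methoxyphenyl on a saturated chain carbon bound to an aromatic nitrogen, or 2-methoxybenzyl to ethyl when cut one bond further out.

For the measured compounds named here, only one measured step bears on this change: a step that the two limits leave unreadable from compound 1 to compound 3, with benzyl in place of hydrogen on an aromatic nitrogen. It has no readable size, so it supplies neither a magnitude nor a direction. No step beyond the scatter is therefore expected in this assay, and compound 4 is expected to report as a limit too. The estimated step that the limit leaves unreadable from compound 2 to compound 4 is nominal, since it starts from a limit. For compound 4 the estimated value is 15000 nM, with an expected range from 4000 nM to 50000 nM.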

Compound 4, half-maximal inhibitory concentration: > 10000 nM
Compound 4 ended at the assay's limit (the forecaster's own chance of this, stated with the estimate: 80%); the middle value lies beyond the limit too.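

In this assay compound 4 gives > 10000 nM as a limit and not a number. For the compounds shown here, compound 2 also stands only at a limit, so the step between compound 2 and compound 4 cannot be read, and no new step comes from this result. The compounds shown leave open which change to the shared core, if any, would give a readable value.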